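Adding fluoro to the benzoyl group of compound 2

The compounds below may be only part of what the source reports. "The series", "measured", "known", "first", "only" and "open" are said of these compounds alone.

- compound 1 `COc1ccc(C(=O)c2cc(C)ccc2OCC(=O)NNC(=O)c2cc3ccccc3oc2=O)cc1`: 43400 nM
- compound 2 `Cc1ccc(OCC(=O)NNC(=O)c2cc3ccccc3oc2=O)c(C(=O)c2ccccc2)c1`: 87000 nM

In a functional assay on DLA cells (Mus musculus) for cytotoxicity, read by LDH release, with a stated time of 48 h (on this read-out lower numbers stand for stronger inhibition and higher numbers for weaker inhibition), compound 2 gives 87000 nM, within the usual scatter of compound 1 at 43400 nM. Compound 3 `Cc1ccc(OCC(=O)NNC(=O)c2cc3ccccc3oc2=O)c(C(=O)c2ccc(F)cc2)c1` differs from compound 2 in one place: fluoro in place of hydrogen on an aromatic carbon. Going by the values given here, the only measured step, a 2.0-fold higher number from compound 1 to compound 2 (0.30 log units; within the scatter), also exchanges one small group on an aromatic carbon and stays within the scatter. A single step is thin evidence, but no change beyond the scatter is expected in this assay. The expected change is a 1.3-fold lower number from compound 2 to compound 3 (0.13 log units; within the scatter). For compound 3 the estimated value is 65000 nM, with an expected range of 28000 nM to 150000 nM.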

Compound 3, half-maximal inhibitory concentration: 45700 nM
Estimate against measurement, compound 3: 1.4-fold (0.15 log units) above, within the range that was stated.
By their numbers in this assay, from the lowest: compounds 1, 3 and 2 (each within the scatter of the next).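

Fluoro is the third group seen on this aromatic carbon of the benzoyl group, and putting it in place of hydrogen gives a 1.9-fold lower number from compound 2 to compound 3 (0.28 log units; within the scatter). Putting it in place of methoxy gives a 1.1-fold higher number from compound 1 to compound 3 (0.02 log units; within the scatter). Hydrogen, methoxy and fluoro therefore cannot be told apart at this position, and no measurement given here offers an explanation for these numbers. Going by these compounds, whether an amine, a carboxylic acid or a longer chain on this carbon would give a step beyond the scatter remains open.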